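Furan-3-yl for Ethynyl on a Nucleoside Core

A few compounds are considered here, and "the series" means these few. Any claim that something is new, unique, unknown or untested is made for them only; others in the source may bear on it.

Compound 1, `C#Cc1cn([C@@H]2O[C@H](CO)[C@@H](O)[C@H]2O)c2ncnc(C)c12`: in a functional assay on HCT-116 cells (Homo sapiens), read by MTT assay, with a stated time of 72 h (a lower number here means a stronger inhibitor, a higher number a weaker inhibitor), compound 1 reaches only a limit of the assay, > 20000 nM.
Compound 2, `Cc1ncnc2c1c(-c1ccoc1)cn2[C@@H]1O[C@H](CO)[C@@H](O)[C@H]1O`: in this assay compound 2 likewise reaches only a limit, > 20000 nM.
Compound 3, `C#Cc1cn([C@@H]2O[C@H](CO)[C@@H](O)[C@H]2O)c2nc(N)nc(OC)c12`: in this assay compound 3 also gives only a limit, > 20000 nM.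

Compound 4, `COc1nc(N)nc2c1c(-c1ccoc1)cn2[C@@H]1O[C@H](CO)[C@@H](O)[C@H]1O`, has not been measured. It differs from compound 3 by furan-3-yl in place of ethynyl on an aromatic carbon. The same change was already made from compound 1 to compound 2, (furan-3-yl in place of ethynyl on an aromatic carbon), and there the step that the two limits leave unreadable from compound 1 to compound 2. How the cores of compound 1 and compound 3 differ is not broken down here. For compound 4 the step that the limit leaves unreadable from compound 3 to compound 4 is expected to stay unreadable, because every measured value sits at the limit of > 20000 nM in this assay, at which 3 of the 3 values shown sit. Compound 4 is therefore estimated at 30000 nM, most likely again reported only as a limit.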

Compound 4, half-maximal inhibitory concentration: > 20000 nM
Compound 4 was reported as a limit; the forecaster's own chance of this, stated with the estimate: 85%; the middle value does not contradict the limit.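

No step can be read from compound 3 to compound 4, as neither gives a number: the limit of > 20000 nM in this assay, at which 4 of the 4 values shown sit. The compounds shown leave open how furan-3-yl and ethynyl compare on either core.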